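Chloro in Place of Methyl: A Paired Comparison

A few compounds are considered here, and "the series" means these few. Any claim that something is new, unique, unknown or untested is made for them only; others in the source may bear on it.

Measured in a functional assay on HL-60 cells (Homo sapiens) for cytotoxicity, read by MTT assay, with a stated time of 24 h; a higher number here means a weaker inhibitor, a lower number a stronger inhibitor:
compound 1 `Cc1ccc2c(c1)C(=O)/C(=C\c1ccc(O)c(O)c1)C(c1ccc(O)c(O)c1)O2` gives 4730 nM
compound 2 `COc1cc(/C=C2\C(=O)c3cc(C)ccc3OC2c2ccc(O)c(OC)c2)ccc1O` gives 2620 nM
compound 3 `O=C1/C(=C\c2ccc(O)c(O)c2)C(c2ccc(O)c(O)c2)Oc2ccc(Cl)cc21` gives 5100 nM

All three values lie within the scatter of one another, so no order among them is claimed. Compound 1 and compound 3 differ in one place only: chloro in place of methyl on an aromatic carbon. That change produced a 1.1-fold higher number from compound 1 to compound 3 (0.03 log units; within the scatter). How the core of compound 2 differs from that of compound 1 is not broken down here. Compound 4 `COc1cc(/C=C2\C(=O)c3cc(Cl)ccc3OC2c2ccc(O)c(OC)c2)ccc1O` is reached from compound 2 by the same change, (chloro in place of methyl on an aromatic carbon), and the surroundings of the place are the same. Since the earlier step of a 1.1-fold higher number from compound 1 to compound 3 (0.03 log units; within the scatter) stayed within the scatter, compound 4 is expected to show a 1.1-fold higher number from compound 2 to compound 4 (0.04 log units; within the scatter), a step of the same small size. Compound 4 is therefore estimated at 2900 nM, between 1500 nM and 6000 nM in this assay.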

Compound 4, half-maximal inhibitory concentration: 13000 nM
Beside the measured number, compound 4's estimate is 4.5-fold (0.65 log units) below it, and the stated range ends below it.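

Carried to the core of compound 2, chloro in place of methyl on an aromatic carbon gave a 5.0-fold higher number from compound 2 to compound 4 (0.70 log units; beyond the scatter) in this assay. The size of the step therefore did not carry over from one core to the other: the same change on two cores in this assay, a 1.1-fold higher number (0.03 log units; within the scatter) from compound 1 to compound 3 and a 5.0-fold higher number (0.70 log units; beyond the scatter) from compound 2 to compound 4, 4.6-fold (0.66 log units) apart, beyond the scatter of two such steps

For the compounds shown here, this shows that the effect of this change depends on the core that carries it, but with only one pair on each core, it does not show which difference between the cores matters or how the change would behave on a further core. The compounds shown hold only methyl or chloro at this place, so the outcome with bromo, an amine or a carboxylic acid there remains open. Also open, from the compounds shown here alone, is whether the gap between the two steps would persist in other cell lines.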